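The compounds below may be only part of what the source reports. "The series", "measured", "known", "first", "only" and "open" are said of these compounds alone.

Measured compounds:
compound 1, `CC#CC(CC(=O)O)c1ccc(OCc2ccc(C(=O)N3CCN(c4cccnc4)CC3)s2)cc1`, in a functional assay on HEK293 cells for agonist activity at Free fatty acid receptor 1 (Homo sapiens), read by fluorescence and calcium flux (on this read-out higher numbers stand for an effect only at larger amounts of compound and lower numbers for an effect already at smaller amounts), gives 1140 nM
compound 2, `CC#CC(CC(=O)O)c1ccc(OCc2ccc(C(=O)N3CCN(c4ccc(OC)cc4)CC3)s2)cc1`, in this assay gives 289 nM

Of these two numbers, compound 2 has the lower one; its nearest neighbour is compound 1, and the step between them, a 3.9-fold lower number from compound 1 to compound 2 (0.60 log units; beyond the scatter), lies beyond the scatter. Compound 3, `CC#CC(CC(=O)O)c1ccc(OCc2ccc(C(=O)N3CCN(c4ccc([N+](=O)[O-])cc4)CC3)s2)cc1`, has not yet been measured. It differs from compound 2 by nitro in place of methoxy on an aromatic carbon. Among the measured compounds shown here, the only measured step, a 3.9-fold lower number from compound 1 to compound 2 (0.60 log units; beyond the scatter), concerns an exchange of the whole ring on the amine nitrogen, not of a group on that ring, so it does not bear directly on the present change. For the measured compounds named here, with no measured step of this kind, the step from compound 2 to compound 3 is expected to be a 1.4-fold higher number from compound 2 to compound 3 (0.14 log units; within the scatter), that is, nothing clearly beyond the scatter in either direction. Compound 3 is therefore estimated at 400 nM in this assay, with a range from 130 nM to 1300 nM.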

Compound 3, half-maximal effective concentration: 231 nM
The estimate for compound 3 lay 1.7-fold (0.24 log units) above the measured number; the range from low to high includes it.
By their numbers in this assay, from the lowest: compounds 3 and 2 (each within the scatter of the next); then compound 1.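

In this assay, the exchange of methoxy for nitro on an aromatic carbon, para to a large group, gives a 1.3-fold lower number from compound 2 to compound 3 (0.10 log units; within the scatter), so this position tolerates the exchange of one of these groups for the other without a change that can be told from the scatter. The exchange of the whole ring is again a clear one, with a 4.9-fold lower number from compound 1 to compound 3 (0.69 log units; beyond the scatter), which places the 4-nitrophenyl compound, like the 4-methoxyphenyl compound, apart from the pyridin-3-yl compound. Nothing given here explains why the two groups read alike at this position.

The compounds shown leave open whether a plain phenyl ring on the amine nitrogen would read like compound 1 or like compounds 2 and 3. They also leave open whether an amine or a trifluoromethyl group at this position would stay within the scatter of compound 2.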